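Nitrophenyl for methoxyphenyl on the double-bonded chain carbon

The source may hold more compounds than are shown below. What is called first, only, known or untested is meant among the compounds shown, and "the series" means these compounds.

Compound 2 `COc1cccc(/C=C/C(=O)Nc2cc(C(=O)c3cc(OC)c(OC)c(OC)c3)ccc2OC)c1` gives 3100 nM in a functional assay on HeLa cells (Homo sapiens) for cytotoxicity, read by MTT assay, with a stated time of 72 h; a higher number here means a weaker inhibitor, a lower number a stronger inhibitor. Among the three measured compounds it holds the second highest number: its nearest neighbour, compound 1 `COc1ccc(C(=O)c2cc(OC)c(OC)c(OC)c2)cc1NC(=O)/C=C/c1cc(OC)c(OC)c(OC)c1`, gives 1500 nM, and the furthest, compound 3 `COc1ccc(C(=O)c2cc(OC)c(OC)c(OC)c2)cc1NC(=O)/C=C/c1ccc(N)cc1`, gives 14700 nM. The steps between them read a 2.1-fold higher number from compound 1 to compound 2 (0.32 log units; beyond the scatter) and a 4.7-fold higher number from compound 2 to compound 3 (0.68 log units; beyond the scatter), with a 9.8-fold higher number from compound 1 to compound 3 (0.99 log units; beyond the scatter) spanning both.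

Compound 4 `COc1ccc(C(=O)c2cc(OC)c(OC)c(OC)c2)cc1NC(=O)/C=C/c1ccc([N+](=O)[O-])cc1` differs from compound 2 in one place: 4-nitrophenyl in place of 3-methoxyphenyl on a double-bonded chain carbon bound to a double-bonded chain carbon. Within the data shown here, two measured steps touch this same place. Replacing the 3,4,5-trimethoxyphenyl of compound 1 by the 3-methoxyphenyl of compound 2 gave a 2.1-fold higher number from compound 1 to compound 2 (0.32 log units; beyond the scatter), and replacing that 3-methoxyphenyl by the 4-aminophenyl of compound 3 gave a 4.7-fold higher number from compound 2 to compound 3 (0.68 log units; beyond the scatter). Among the measured compounds shown here, no measured compound carries a nitro group, so the size of the step is uncertain, but the one departure from compound 2 at this place so far raised the number, and a modest rise in this assay is therefore expected. Compound 4 is estimated at 6000 nM, within a range from 2000 nM to 20000 nM. That estimate means an expected step of a 1.9-fold higher number from compound 2 to compound 4 (0.29 log units; within the scatter).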

Compound 4, half-maximal inhibitory concentration: 8500 nM
For compound 4 the middle estimate is 1.4-fold (0.15 log units) below the measured one; the range from low to high includes it.
By their numbers in this assay, from the lowest: compound 1; then compound 2; then compounds 4 and 3 (each within the scatter of the next).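

In this assay, the 4-nitrophenyl group gives a second case in which a group at this place ends higher than the 3-methoxyphenyl group (a 2.7-fold higher number from compound 2 to compound 4 (0.44 log units; beyond the scatter)), as the 4-aminophenyl group did, while the 3,4,5-trimethoxyphenyl group of compound 1 goes against that direction (a 5.7-fold higher number from compound 1 to compound 4 (0.75 log units; beyond the scatter)). Nitro in place of amino on an aromatic carbon leaves the two compounds inseparable (a 1.7-fold lower number from compound 3 to compound 4 (0.24 log units; within the scatter)), so these two groups cannot be ranked in this assay. Nothing available explains these steps.

The compounds shown leave open how an unsubstituted phenyl or a 4-methoxyphenyl group at this place would compare with compound 2. They also leave open whether a 4-hydroxyphenyl group or a 4-carboxyphenyl group would fall with compound 3 and compound 4.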